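Cyclopentyl to cyclohexyl amides: inhibition notes on the series

The compounds below may be only part of what the source reports. "The series", "measured", "known", "first", "only" and "open" are said of these compounds alone.

Compound 1 `CC(C)C(NC(=O)NO)C(=O)NC1CCCCC1`, compound 2 `CC(C)C(NC(=O)NO)C(=O)NC1CCCC1` and compound 3 `CC(C)C(NC(=O)n1nnc2ccccc21)C(=O)NC1CCCC1` have been tested in a functional assay on MOLT-4 cells (Homo sapiens) for inhibition; on this read-out higher numbers stand for weaker inhibition and lower numbers for stronger inhibition; compound 4 `CC(C)C(NC(=O)n1nnc2ccccc21)C(=O)NC1CCCCC1` has not yet been tested. In this assay compound 1 gives only a limit, > 100000 nM. Compound 2 likewise gives only a limit, > 200000 nM. Compound 3 also gives only a limit, > 200000 nM. Two limits occur among the three values: the limit of > 100000 nM in this assay, at which 1 of the 3 values shown sits, and (the limit of > 200000 nM in this assay, at which 2 of the 3 values shown sit).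

Compound 2 and compound 1 differ in one place, (cyclohexyl in place of cyclopentyl on an amide-type nitrogen), and in this assay that change gives a step that the two limits leave unreadable from compound 2 to compound 1. Compound 3 and compound 4 differ by the same change, (cyclohexyl in place of cyclopentyl on an amide-type nitrogen); the place reads word for word the same, so it is the same change and not merely the same kind. How the core of compound 3 differs from the core of compound 2 is not broken down here.

With the measured instance of the change unreadable and all three values resting at limits, compound 4 is expected to sit at a limit as well. The step from compound 3 to compound 4 in this assay is expected to be a number no higher from compound 3 to compound 4 (the limit leaves the size open), and this expectation rests on the earlier step that the two limits leave unreadable from compound 2 to compound 1. Compound 4 is estimated at 200000 nM, with a range from 100000 nM to 500000 nM, most probably reported again only as a limit.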

Compound 4, half-maximal inhibitory concentration: 97000 nM
Compound 4: middle estimate off by 2.1-fold (0.31 log units), on the high side; measured number outside the range, below it.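

In this assay, cyclohexyl in place of cyclopentyl on an amide-type nitrogen gives an at least 2.0-fold lower number from compound 3 to compound 4 (0.31 log units; beyond the scatter), so on the core of compound 3 the change goes with stronger inhibition, and the step is a minimum size and not an exact one. On the core of compound 2 the same change cannot be read, since the values of compound 2 and compound 1 are both limits and give neither a direction nor a size. The change therefore has only one readable instance in this series, which means that carrying it from one core to the other is neither confirmed nor contradicted, and nothing shown establishes that the step on one core predicts the step on the other.

The compounds shown leave open how cycloheptyl, a longer chain, an amine or a carboxylic acid in place of the cyclohexyl on the amide-type nitrogen would read on either core. They also leave open whether cyclohexyl on the core of compound 1 differs from cyclopentyl at all once both values can be read as numbers in this assay.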